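Phenyl Replaces Methyl on the Sulfonyl Sulfur

The source may report more compounds than this note shows. Statements on the series, on what has been measured and on what is new or still open speak of the compounds shown alone.

Of the compounds shown here, three of a shared core have been measured in an assay on HEK293 cells for displacement of a labelled ligand from NPC1-like intracellular cholesterol transporter 1 (Homo sapiens); a higher number here means a weaker inhibitor, a lower number a stronger inhibitor. Compound 1 `CC(C)(C)c1ccc(C(=O)N2CCC3(CC2)C(=O)N(CC(=O)N2CCN(S(C)(=O)=O)CC2)CN3c2ccccc2)cc1` gives 19000 nM, compound 2 `CC(C)(C)OC(=O)N1CCN(C(=O)CN2CN(c3ccccc3)C3(CCN(C(=O)c4ccc(C5CCCCC5)cc4)CC3)C2=O)CC1` gives 3500 nM, and compound 3 `CS(=O)(=O)N1CCN(C(=O)CN2CN(c3ccccc3)C3(CCN(C(=O)c4ccc(C5CCCCC5)cc4)CC3)C2=O)CC1` gives 6300 nM. Compound 3 thus holds the second highest of the three numbers: its nearest neighbour is compound 2, within the scatter, while compound 1 lies beyond it, as the step of a 3.0-fold lower number from compound 1 to compound 3 (0.48 log units; beyond the scatter) shows.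

Compound 4 `O=C(CN1CN(c2ccccc2)C2(CCN(C(=O)c3ccc(C4CCCCC4)cc3)CC2)C1=O)N1CCN(S(=O)(=O)c2ccccc2)CC1` differs from compound 3 in one place: phenyl in place of methyl on a sulfonyl sulfur. Going by the values given here, the only measured step touching that region is a 1.8-fold higher number from compound 2 to compound 3 (0.26 log units; within the scatter), which swapped one group on the ring nitrogen for another without a change beyond the scatter. The step from compound 1 to compound 3 concerns the aromatic carbon and bears little here. The author therefore expects compound 4 to sit close to compound 3 in this assay, with a step of a 1.3-fold lower number from compound 3 to compound 4 (0.10 log units; within the scatter) that need not exceed the scatter. The estimate for compound 4 is 5000 nM, within a range from 1500 nM to 16000 nM.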

Compound 4, half-maximal inhibitory concentration: 14200 nM
Compound 4: middle estimate off by 2.8-fold (0.45 log units), on the low side; the range from low to high includes it.
By their numbers in this assay, from the lowest: compounds 2 and 3 (each within the scatter of the next); then compounds 4 and 1 (each within the scatter of the next).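

Going by these compounds alone, the group on the sulfonyl sulfur does register in this assay: a 2.3-fold higher number from compound 3 to compound 4 (0.35 log units; beyond the scatter) lies beyond the scatter, whereas the only earlier swap on this ring nitrogen, a 1.8-fold higher number from compound 2 to compound 3 (0.26 log units; within the scatter), stayed within it. Against the tert-butoxycarbonyl group on the same amine nitrogen, phenylsulfonyl gives a 4.1-fold higher number from compound 2 to compound 4 (0.61 log units; beyond the scatter), so compound 4 carries a higher number than both compound 2 and compound 3. Nothing among the available data offers an explanation for this rise.

Going by these compounds, whether the rise follows from the aromatic ring itself or simply from a larger group on the sulfur remains open, and an ethyl or a cyclohexyl on the sulfonyl sulfur would bear on that question. Also open, on these data alone, is whether the same step would appear with tert-butyl in place of cyclohexyl on the aromatic carbon.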